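Sulfonyl group swap from compound 3 to compound 4

The source may report more compounds than this note shows. Statements on the series, on what has been measured and on what is new or still open speak of the compounds shown alone.

Measured in a functional assay on VCaP cells (Homo sapiens) for antiproliferative activity, read by CCK-8 assay, with a stated time of 6 days; a lower number here means a stronger inhibitor, a higher number a weaker inhibitor:
- compound 1 `C[C@@H](Cn1ccc(-c2ccc(C#N)c(Cl)c2)n1)NC(=O)c1ccccc1F`: 2190 nM
- compound 2 `COC(=O)/C=C/C(=O)N[C@@H](C)Cn1ccc(-c2ccc(C#N)c(Cl)c2)n1`: 5230 nM
- compound 3 `C[C@@H](Cn1ccc(-c2ccc(C#N)c(Cl)c2)n1)NS(=O)(=O)c1cccnc1`: 2450 nM

The lower end of this small range is shared, with a 1.1-fold higher number from compound 1 to compound 3 (0.05 log units; within the scatter), while a 2.1-fold lower number from compound 2 to compound 3 (0.33 log units; beyond the scatter). Compound 4 `C[C@@H](Cn1ccc(-c2ccc(C#N)c(Cl)c2)n1)NS(=O)(=O)c1cn(C)cn1` carries 1-methyl-1H-imidazol-4-yl in place of pyridin-3-yl on a sulfonyl sulfur. Among the measured compounds shown here, no measured step changes only this group. The nearest evidence is indirect, from wider changes on the amine nitrogen, and the largest of these is a 2.4-fold higher number from compound 1 to compound 2 (0.38 log units; beyond the scatter). A step beyond the scatter is therefore not expected in this assay, and no direction is favoured. The expected step is a 1.1-fold higher number from compound 3 to compound 4 (0.06 log units; within the scatter). For compound 4 the estimated value is 2800 nM, with an expected range of 1300 nM to 6000 nM.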

Compound 4, half-maximal inhibitory concentration: 13600 nM
For compound 4 the middle estimate is 4.9-fold (0.69 log units) below the measured one, outside the stated range (above it).
By their numbers in this assay, from the lowest: compounds 1 and 3 (each within the scatter of the next); then compound 2; then compound 4.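

In this assay the group on the sulfonyl sulfur matters: 1-methyl-1H-imidazol-4-yl in place of pyridin-3-yl, with the heavy-atom count unchanged, gives a 5.6-fold higher number from compound 3 to compound 4 (0.74 log units; beyond the scatter). A sulfonamide on the amine nitrogen therefore does not by itself set the number, as compound 3 alone suggested. Compound 4 also reads higher than both carbonyl compounds, with a 2.6-fold higher number from compound 2 to compound 4 (0.42 log units; beyond the scatter) and a 6.2-fold higher number from compound 1 to compound 4 (0.79 log units; beyond the scatter).

No measured property here accounts for the step. As far as these compounds go, whether a phenyl or a methyl group on the sulfonyl sulfur would read nearer compound 3 or compound 4 remains open.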